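Swapping the chlorophenyl for a difluorophenyl on the pyridazinone nitrogen

A few compounds are considered here, and "the series" means these few. Any claim that something is new, unique, unknown or untested is made for them only; others in the source may bear on it.

Measured so far:
- compound 1 `COc1ccc(-n2nc(C(=O)Nc3ccc(Oc4ccnc5cc(OCCCN6CCCC6)c(OC)cc45)c(F)c3)c(C)cc2=O)cc1` — 2770 nM
- compound 2 `COc1cc2c(Oc3ccc(NC(=O)c4nn(-c5ccc(Cl)cc5)c(=O)cc4C)cc3F)ccnc2cc1OCCCN1CCCC1` — 230 nM

Both compounds were tested in a functional assay on A549 cells (Homo sapiens) for inhibition, read by MTT assay, with a stated time of 72 h; on this read-out higher numbers stand for weaker inhibition and lower numbers for stronger inhibition. Compound 1 gives 2770 nM in this assay, and compound 2 gives 230 nM. Among the compounds with values here, the one measured step, a 12-fold lower number from compound 1 to compound 2 (1.08 log units; beyond the scatter), changes only the group on the aromatic nitrogen of the shared core. Compound 2 therefore stands with the lowest of the two numbers, and its nearest neighbour, compound 1, lies well beyond the scatter above it.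

Compound 3 `COc1cc2c(Oc3ccc(NC(=O)c4nn(-c5ccc(F)c(F)c5)c(=O)cc4C)cc3F)ccnc2cc1OCCCN1CCCC1` has not yet been measured. It differs from compound 2 by 3,4-difluorophenyl in place of 4-chlorophenyl on an aromatic nitrogen. Within the data shown here, the only step that bears on this position is the one from compound 1 to compound 2, which was large, but it exchanged a methoxy group for a chloro group rather than a chloro group for two fluorine atoms, so the size of the expected effect is uncertain. Compound 3 is expected to stay in the neighbourhood of compound 2, with an estimated step of a 1.7-fold higher number from compound 2 to compound 3 (0.24 log units; within the scatter) in this assay. The estimate for compound 3 is 400 nM, with a range from 120 nM to 1300 nM.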

Compound 3, half-maximal inhibitory concentration: 220 nM
Compound 3: the middle estimate sits 1.8-fold (0.26 log units) above what was measured; low and high end bracket the measured number.
By their numbers in this assay, from the lowest: compounds 3 and 2 (each within the scatter of the next); then compound 1.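

In this assay, replacing 4-chlorophenyl with 3,4-difluorophenyl on the aromatic nitrogen gives a 1.0-fold lower number from compound 2 to compound 3 (0.02 log units; within the scatter) and so leaves the read-out unchanged within the scatter, which shows that this position accepts two different halogen patterns with no measurable difference. The earlier step, a 12-fold lower number from compound 1 to compound 2 (1.08 log units; beyond the scatter), could have pointed to something specific to the chlorine, but the new step, a 13-fold lower number from compound 1 to compound 3 (1.10 log units; beyond the scatter), is also large, so that gap from the 4-methoxyphenyl compound is not tied to chlorine alone. Among these three compounds, compound 1 stands apart while compound 2 and compound 3 cannot be separated, and no measurement shown here explains this difference.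

The compounds shown leave open how an unsubstituted phenyl ring, a 4-trifluoromethylphenyl group or a 4-aminophenyl group would read at this nitrogen, and therefore whether the 4-methoxyphenyl result reflects the methoxy group specifically or a wider set of substituents. They also leave open whether the match between compound 2 and compound 3 would hold in any cell line other than the one used here.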